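A few compounds are considered here, and "the series" means these few. Any claim that something is new, unique, unknown or untested is made for them only; others in the source may bear on it.

The series rests on two measured compounds. Compound 1 `N#C/C(=C\c1ccccc1OS(=O)(=O)c1ccc(Cl)cc1)C(=O)Nc1nnc(Cc2cccc3ccccc23)s1` and compound 2 `COc1ccc(S(=O)(=O)Oc2ccccc2/C=C(\C#N)C(=O)Nc2nnc(Cc3ccc(Cl)cc3)s2)cc1` were both tested in a functional assay on HL-60 cells (Homo sapiens) for inhibition, read by CCK-8 assay, with a stated time of 48 h, tested at 20 uM; on this read-out higher numbers stand for more inhibition of growth at the one concentration tested and lower numbers for less inhibition of growth. In this assay compound 1 gives 15%, while compound 2 gives 99%, the higher of the two numbers shown; the gap from compound 1 to compound 2 lies beyond the scatter. Among the compounds with values here, the two compounds differ in more than one place, so no single step is available between them, and their values can only be read side by side.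

Compound 3 `N#C/C(=C\c1ccccc1OS(=O)(=O)c1ccc(Cl)cc1)C(=O)Nc1nnc(Cc2ccc(Cl)cc2)s1` has not been measured in this assay. It is reached from compound 2 by one change: chloro in place of methoxy on an aromatic carbon. Compound 3 differs in a second place from compound 1, which also carries the (4-chlorophenyl)sulfonyl group, so the value that compound 1 gives, 15%, cannot be tied to this change alone.

Given this, the step from compound 2 to compound 3 is expected to be a drop, a number 39 percentage points lower from compound 2 to compound 3 (beyond the scatter), beyond the scatter but with wide uncertainty. Compound 3 is therefore estimated at 60%, with a range from 15% to 99%.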

Compound 3, percent growth inhibition at one concentration: 15%
Compound 3: middle estimate off by 45 percentage points, on the high side; low and high end bracket the measured number.
By their numbers in this assay, from the lowest: compounds 1 and 3 (each within the scatter of the next); then compound 2.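

In this assay, within the data shown here, the exchange of methoxy for chloro on an aromatic carbon, para to a large group, now stands as a single step, a number 84 percentage points lower from compound 2 to compound 3 (beyond the scatter), so this position can be read on its own for the first time and it carries a large effect on growth inhibition. The second step shows something compound 1 alone could not: with (4-chlorophenyl)sulfonyl held in place, 4-chlorophenyl in place of naphthalen-1-yl on the saturated chain carbon gives no change at the digits printed from compound 1 to compound 3 (within the scatter), so that exchange does not register here, while the exchange at the sulfonyl side accounts for the whole gap between compound 2 and compound 3. Nothing on hand gives a reason for the size of this step.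

The compounds shown leave open whether high growth inhibition belongs to methoxy in particular or would also appear with a hydroxy group, an amine or a longer ethoxy chain at this place. They also leave open whether naphthalen-1-yl would remain without effect when paired with (4-methoxyphenyl)sulfonyl rather than (4-chlorophenyl)sulfonyl.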